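Bromo to methyl on the fused ring: working notes

The source may report more compounds than this note shows. Statements on the series, on what has been measured and on what is new or still open speak of the compounds shown alone.

Measured so far in a functional assay on MCF7 cells (Homo sapiens) for antiproliferative activity, read by MTT assay, with a stated time of 48 h; on this read-out higher numbers stand for weaker inhibition and lower numbers for stronger inhibition
- compound 1 `Fc1ccc(-c2nn(-c3ccccc3)cc2-c2nc3ccccc3[nH]2)cc1` gives 3200 nM
- compound 2 `Fc1ccc(-c2nn(-c3ccccc3)cc2-c2nc3cc(F)ccc3[nH]2)cc1` gives 950 nM
- compound 3 `Fc1ccc(-c2nn(-c3ccccc3)cc2-c2nc3cc(Br)ccc3[nH]2)cc1` gives 3210 nM

Compound 3 lies within the scatter of the hydrogen analogue (a 1.0-fold higher number from compound 1 to compound 3 (0.00 log units; within the scatter)) and above the fluoro analogue by a modest margin (a 3.4-fold higher number from compound 2 to compound 3 (0.53 log units; beyond the scatter)). The next compound is compound 4 `Cc1ccc2[nH]c(-c3cn(-c4ccccc4)nc3-c3ccc(F)cc3)nc2c1`, which has methyl in place of bromo on an aromatic carbon. For the measured compounds named here, no methyl compound has been measured yet, so the evidence is indirect. Bromo in place of hydrogen gave no step beyond the scatter (a 1.0-fold higher number from compound 1 to compound 3 (0.00 log units; within the scatter)), whereas fluoro in place of hydrogen gave a modest one (a 3.4-fold lower number from compound 1 to compound 2 (0.53 log units; beyond the scatter)). Three compounds support no trend across these groups, so only a small shift toward lower numbers in this assay is expected, and no step beyond the scatter. The expected step is a 1.4-fold lower number from compound 3 to compound 4 (0.14 log units; within the scatter) as estimated here. The estimate for compound 4 is 2300 nM, with an expected range from 900 nM to 5500 nM.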

Compound 4, half-maximal inhibitory concentration: 1120 nM
Compound 4: middle estimate off by 2.1-fold (0.31 log units), on the high side; low and high end bracket the measured number.
By their numbers in this assay, from the lowest: compounds 2 and 4 (each within the scatter of the next); then compounds 1 and 3 (each within the scatter of the next).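

In this assay, for the compounds shown here, methyl separates from bromo on this aromatic carbon (a 2.9-fold lower number from compound 3 to compound 4 (0.46 log units; beyond the scatter)) and from hydrogen (a 2.9-fold lower number from compound 1 to compound 4 (0.46 log units; beyond the scatter)), so fluoro is no longer the only group here to give a step beyond the scatter from hydrogen. Methyl and fluoro show no separation (a 1.2-fold higher number from compound 2 to compound 4 (0.07 log units; within the scatter)), which leaves two levels in the series: methyl with fluoro, and bromo with hydrogen. Nothing at hand accounts for this split among the four groups.

From the compounds shown here alone, whether these two levels hold for other groups stays open: an amine, a methoxy group or a carboxylic acid on the same carbon would test this. Going by these compounds, it also stays open whether methyl and fluoro keep their standing on other aromatic carbons of the shared core.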